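A few compounds are considered here, and "the series" means these few. Any claim that something is new, unique, unknown or untested is made for them only; others in the source may bear on it.

Among the compounds with values here, compound 3 `FC(F)(F)Oc1ccc(Nc2cc(-c3cccc4[nH]ccc34)ncn2)cc1` is the only compound of this set that gives a number rather than a limit in an ADME assay on BaF3 cells (Mus musculus) for cytotoxicity (a higher number here means that more compound is needed for the effect, a lower number that less compound is needed), where compound 3 gives 3790 nM. Compound 1 `O=C(O)c1cc2c(Nc3ccc(OC(F)(F)F)cc3)ncnc2s1` reaches only a limit of this assay, > 10000 nM. Compound 2 `CCNC(=O)c1cc2c(Nc3ccc(OC(F)(F)F)cc3)ncnc2s1` likewise reaches only a limit of this assay, > 10000 nM. Within the data shown here, the one step between measured compounds, a step that the two limits leave unreadable from compound 1 to compound 2, therefore cannot be read in size, as the limit of > 10000 nM in this assay, at which 2 of the 3 values shown sit, makes plain: the two values sit at the same limit. Compound 4 `NC(=O)c1ccccc1-c1cc(Nc2ccc(OC(F)(F)F)cc2)ncn1` differs from compound 3 by 2-carbamoylphenyl in place of 1H-indol-4-yl on an aromatic carbon. Among the measured compounds shown here, none of the measured steps touches this part of the structure, and the one step that exists, between compound 1 and compound 2, is itself unreadable, so no measured step bears directly on the change from compound 3 to compound 4. For the measured compounds named here, with the two other compounds sitting at the limit and compound 3 the sole number, compound 4 is expected to move in the direction of the limit, and its step of a 1.6-fold higher number from compound 3 to compound 4 (0.20 log units; within the scatter) is estimated as modest and within or just beyond the usual scatter. Compound 4 is expected to give 6000 nM in this assay, with a range from 2000 nM to 20000 nM.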

Compound 4, half-maximal effective concentration: > 10000 nM
Compound 4 gave a limit, no number (the forecaster's own chance of this, stated with the estimate: 40%); at least 1.6-fold (0.22 log units) between middle value and limit.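

In this assay, 2-carbamoylphenyl in place of 1H-indol-4-yl on this aromatic carbon, next to the ring nitrogen, gives an at least 2.6-fold higher number from compound 3 to compound 4 (0.42 log units; beyond the scatter). Within the data shown here, this is the first step in the set whose size can be read at all, and it shows that the group at this one position can move the read-out by more than the scatter, which nothing among the earlier compounds could show. Of the two aryl groups compared here, only 1H-indol-4-yl goes with a number, and compound 3 remains the sole compound to give one, while the set as a whole now leans towards the limit: the limit of > 10000 nM in this assay, at which 3 of the 4 values shown sit.

From the compounds shown here alone, the true size of the new step stays open, as the limit of compound 4 sets only its lower end, and the step between the two compounds that share the other core still cannot be read. Going by these compounds, it is also open whether a plain phenyl group, or a phenyl group carrying a carboxylic acid or an aminomethyl group in place of the carbamoyl, would give a number at this position in this assay.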